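The source may hold more compounds than are shown below. What is called first, only, known or untested is meant among the compounds shown, and "the series" means these compounds.

Compound 1 `Cn1nc2c(=O)n(CC3(O)CCN(Cc4ccc(-c5ccco5)cc4Cl)CC3)cnc2c1-c1ccc(C2(N)CC2)cc1`: 1.99 10^-6 cm/s
Compound 2 `Cn1nc2c(=O)n(CC3(O)CCN(Cc4ccc(-c5cnco5)cc4Cl)CC3)cnc2c1-c1ccc(CN)cc1`: 0.86 10^-6 cm/s

In an ADME assay on Caco-2 cells (Homo sapiens) for permeability, in the apical to basolateral direction (a lower number here means that the compound crosses the layer more slowly, a higher number that the compound crosses the layer faster), compound 2 has the lower of the two numbers, and its gap to compound 1 lies beyond the usual scatter. Compound 3 `Cn1nc2c(=O)n(CC3(O)CCN(Cc4ccc(C5=CCCC5)cc4Cl)CC3)cnc2c1-c1ccc(CN)cc1` keeps the structure of compound 2 but carries cyclopent-1-en-1-yl in place of 1,3-oxazol-5-yl on an aromatic carbon. Going by the values given here, no measured pair shows this exchange, so the expectation is only a rough one, starting from compound 2 at 0.86 10^-6 cm/s. A modest upward change is expected, estimated as a 1.7-fold higher number from compound 2 to compound 3 (0.24 log units; within the scatter). For compound 3 the estimated value is 1.5 10^-6 cm/s, with an expected range of 0.6 10^-6 cm/s to 4 10^-6 cm/s.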

Compound 3, apparent permeability: 0.23 10^-6 cm/s
Beside the measured number, compound 3's estimate is 6.5-fold (0.81 log units) above it; measured number below the stated range.
By their numbers in this assay, from the lowest: compound 3; then compound 2; then compound 1.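

In this assay, going by these compounds alone, cyclopent-1-en-1-yl in place of 1,3-oxazol-5-yl gives a 3.7-fold lower number from compound 2 to compound 3 (0.57 log units; beyond the scatter), the first step in this set that changes only one place, so the group on this aromatic carbon, para to a large group, does affect the read-out. The exchange keeps the heavy-atom count and removes both hydrogen-bond acceptors of the leaving ring, and the number falls. Nothing measured here bears on why it falls. From the compounds shown here alone, whether a saturated cyclopentyl or a pyridine ring on this carbon would sit nearer compound 2 or compound 3 remains open.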